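This account rests on a few compounds, and the source may have more. Where it says the series, first, only, none or still open, it means among the compounds named here.

In an assay on membranes from lung (Cavia porcellus) for binding affinity to cysteinyl leukotriene receptor (Homo sapiens) (a higher number here means a weaker inhibitor, a lower number a stronger inhibitor), compound 1 `CC(CCc1ccc(OCc2ccc3ccccc3n2)cc1)Cc1nnn[nH]1` gives 25 nM, while compound 2 `CC(CCCC(=O)O)c1cccc(OCc2ccc3ccccc3n2)c1` gives 90 nM, the higher of the two numbers, so compound 2 is the weaker inhibitor of this pair. Compound 3 `CC(Cc1cccc(OCc2ccc3ccccc3n2)c1)CC(C)C(=O)O` is not yet measured in this assay. It differs from compound 2 in one place: 4-carboxy-2-methylpentyl in place of 4-carboxy-1-methylbutyl on an aromatic carbon. Within the data shown here, no step of this kind has been measured here, so the expected step is small, in the direction of a lower number, and it may not reach beyond the scatter; the estimated step is a 1.3-fold lower number from compound 2 to compound 3 (0.11 log units; within the scatter). Compound 3 is therefore expected to give about 70 nM, within a range from 25 nM to 250 nM.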

Compound 3, inhibition constant: 24 nM
Compound 3: the middle estimate sits 2.9-fold (0.46 log units) above what was measured; the measured number lies below the stated range.
By their numbers in this assay, from the lowest: compounds 3 and 1 (each within the scatter of the next); then compound 2.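

In this assay, putting 4-carboxy-2-methylpentyl in place of 4-carboxy-1-methylbutyl on the aromatic carbon gives a 3.8-fold lower number from compound 2 to compound 3 (0.57 log units; beyond the scatter) and so shows that this position is sensitive to the make-up of the chain, even with a carboxy group at the end of both chains. Nothing available accounts for this step. On these data alone, the chain's size and branching change together here, so their separate contributions remain unknown. Also open, as far as these compounds go, is how an unbranched chain, or an amide in place of the carboxylic acid, would behave at this position.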